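The compounds below may be only part of what the source reports. "The series", "measured", "known", "first", "only" and "open" are said of these compounds alone.

Working notes on the series. Among the measured compounds shown here, in an assay on CHO cells for displacement of a labelled ligand from 5-hydroxytryptamine receptor 1B (Homo sapiens) (on this read-out higher numbers stand for weaker inhibition and lower numbers for stronger inhibition), compound 2 `CN(C1CCN(CCCc2c[nH]c3ccc(-n4cnnc4)cc23)CC1)S(=O)(=O)c1ccccc1` gives 10 nM, the lower of the two numbers measured so far; compound 1 `O[C@@H]1Cc2ccccc2[C@H]1NC1CCN(CCCc2c[nH]c3ccc(-n4cnnc4)cc23)CC1` gives 210 nM in this assay, and the single step available, a 21-fold lower number from compound 1 to compound 2 (1.32 log units; beyond the scatter), separates them. Compound 3 `CN(Cc1ccsc1)C1CCN(CCCc2c[nH]c3ccc(-n4cnnc4)cc23)CC1` is not yet measured. It differs from compound 2 by (thiophen-3-yl)methyl in place of phenylsulfonyl on an amine nitrogen. For the measured compounds named here, no measured step bears on this exchange: the step from compound 1 to compound 2 concerns a different group on the same amine nitrogen, so it only shows that this position is sensitive to change and can move the number well beyond the scatter in either direction. With the sulfonyl replaced by an arylmethyl group and nothing measured to anchor it, a moderate rise in the number is expected, a 3.0-fold higher number from compound 2 to compound 3 (0.48 log units; beyond the scatter), with wide uncertainty. Compound 3 is therefore estimated at 30 nM, range 8 nM to 120 nM.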

Compound 3, half-maximal inhibitory concentration: 35 nM
Compound 3: middle estimate off by 1.2-fold (0.07 log units), on the low side; the range from low to high includes it.
By their numbers in this assay, from the lowest: compound 2; then compound 3; then compound 1.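

In this assay, a sulfonyl on this amine nitrogen proves not to be essential for a low number: replacing phenylsulfonyl with (thiophen-3-yl)methyl gives a 3.5-fold higher number from compound 2 to compound 3 (0.54 log units; beyond the scatter), a real but smaller change than the one that separated the first two compounds. Replacing the (2-hydroxy-2,3-dihydro-1H-inden-1-yl)amino group with methyl((thiophen-3-yl)methyl)amino also gives a 6.0-fold lower number from compound 1 to compound 3 (0.78 log units; beyond the scatter), so a non-sulfonyl substituent recovers part of the difference, with compound 3 falling between the other two. No measurement available here accounts for the difference between the sulfonyl and arylmethyl groups.

In this exchange the sulfonyl and the aromatic ring change together, so their separate contributions cannot be read. From the compounds shown here alone, a benzyl group or a thiophen-3-ylsulfonyl group on the same amine nitrogen would bear on that question, and both remain open.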